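Oral exposure in rats across the amine substituent series

The source may report more compounds than this note shows. Statements on the series, on what has been measured and on what is new or still open speak of the compounds shown alone.

Measured compounds in an ADME assay on the whole organism (plasma) for pharmacokinetics, with Rattus norvegicus as the target, with a stated time of 6 h, at a dose of 10 mg/kg by the oral route; on this read-out higher numbers stand for higher exposure at the dose given and lower numbers for lower exposure:
compound 1 `Cc1nc(NC(C)(C)C)nc(N[C@@H]2C[C@H](CO)[C@@H](O)[C@H]2O)c1-c1nc2ccccc2s1` — 2220 ng.h/mL
compound 2 `Cc1nc(NCC2CCC2)nc(N[C@@H]2C[C@H](CO)[C@@H](O)[C@H]2O)c1-c1nc2ccccc2s1` — 228 ng.h/mL

Going by the values given here, compound 2 stands at the lower of the two numbers measured so far; its nearest neighbour is compound 1, and the single measured step runs a 9.7-fold lower number from compound 1 to compound 2 (0.99 log units; beyond the scatter). Among the compounds with values here, that step alters the group on a nitrogen on an aromatic ring, so it is the only comparison available for judging what further exchange at the same position does to exposure.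

Compound 3 `Cc1nc(NCc2cccnc2)nc(N[C@@H]2C[C@H](CO)[C@@H](O)[C@H]2O)c1-c1nc2ccccc2s1` is the next member. Relative to compound 2 the change is pyridin-3-yl in place of cyclobutyl on a saturated chain carbon bound to a nitrogen on an aromatic ring. Within the data shown here, no measured step covers this exchange of a saturated ring for an aromatic one bearing a hydrogen-bond acceptor; the step from compound 1 to compound 2 bears on it only as a precedent for how sensitive this read-out is to the group at this nitrogen. Given that precedent, a step of a 1.9-fold lower number from compound 2 to compound 3 (0.28 log units; within the scatter) is expected, most likely downward, with wide uncertainty. For compound 3 the estimated value in this assay is 120 ng.h/mL, in the range 30 ng.h/mL to 600 ng.h/mL.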

Compound 3, area under the concentration-time curve: 9.57 ng.h/mL
Compound 3: the middle estimate sits 13-fold (1.10 log units) above what was measured; measured number outside the range, below it.
By their numbers in this assay, from the lowest: compound 3; then compound 2; then compound 1.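

In this assay, the group on the nitrogen on an aromatic ring can take exposure well beyond the first drop: with the saturated chain carbon kept in place, pyridin-3-yl in place of cyclobutyl gives a 24-fold lower number from compound 2 to compound 3 (1.38 log units; beyond the scatter), a larger step than a 9.7-fold lower number from compound 1 to compound 2 (0.99 log units; beyond the scatter). The two exchanges run the same way, and together they span a 230-fold lower number from compound 1 to compound 3 (2.37 log units; beyond the scatter), so among these three compounds the amine substituent alone separates the highest exposure from the lowest, with the rest of the structure unchanged. Nothing available accounts for either drop, and the numbers give no reason for the size of the second.

The compounds shown leave open whether the loss in compound 3 goes with the ring nitrogen of pyridin-3-yl or with an aromatic ring on that chain carbon as such, a question that a phenyl ring at the same place would address directly. They also leave open whether the higher number of compound 1 is particular to tert-butyl or extends to other branched groups on that nitrogen, such as isopropyl or 1-methylcyclobutyl.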